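Compound 2 to compound 3: 3-methoxyphenyl becomes 4-methoxyphenyl

The source may report more compounds than this note shows. Statements on the series, on what has been measured and on what is new or still open speak of the compounds shown alone.

Of the compounds shown here, two have numbers so far in a functional assay on A2780 cells (Homo sapiens) for antiproliferative activity, read by MTT assay, with a stated time of 48 h (on this read-out higher numbers stand for weaker inhibition of growth and lower numbers for stronger inhibition of growth), on the shared core. Compound 1 (`COC(=O)N1N=C(c2cccc(OC)c2)CC1c1cc(OC)c(OC)c(OC)c1`) gives 2780 nM and compound 2 (`CCOC(=O)N1N=C(c2cccc(OC)c2)CC1c1cc(OC)c(OC)c(OC)c1`) gives 7300 nM as the higher of the two numbers, which means the weaker inhibition of growth of this pair.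

Compound 3 (`CCOC(=O)N1N=C(c2ccc(OC)cc2)CC1c1cc(OC)c(OC)c(OC)c1`) keeps the ethoxycarbonyl group of compound 2 and differs in one place, with 4-methoxyphenyl in place of 3-methoxyphenyl on a carbon with a double bond to nitrogen. The same atoms are present in both, joined differently.

For the measured compounds named here, the only measured evidence is a 2.6-fold higher number from compound 1 to compound 2 (0.42 log units; beyond the scatter) and that modest step arose within the ester chain, not on the aromatic group. It therefore says nothing direct about this change. Going by the values given here, with no measured pair that alters the methoxyphenyl group, no step beyond the scatter is expected in this assay and neither direction can be favoured.

The expected outcome is a 1.2-fold lower number from compound 2 to compound 3 (0.09 log units; within the scatter) in this estimate. Compound 3 is estimated at 6000 nM with an expected range from 2000 nM to 18000 nM on this read-out.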

Compound 3, concentration for 50% growth inhibition: 9270 nM
Compound 3: the middle estimate sits 1.5-fold (0.19 log units) below what was measured; the range from low to high includes it.
By their numbers in this assay, from the lowest: compound 1; then compounds 2 and 3 (each within the scatter of the next).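

In this assay, the exchange of 3-methoxyphenyl for 4-methoxyphenyl gives a 1.3-fold higher number from compound 2 to compound 3 (0.10 log units; within the scatter), so the two methoxyphenyl groups cannot be told apart at this place on the carbon with a double bond to nitrogen while the ethoxycarbonyl group stays fixed. For the compounds shown here, this is the first measured change on this aromatic group, whereas the earlier step, a 2.6-fold higher number from compound 1 to compound 2 (0.42 log units; beyond the scatter), lay in the ester chain and went beyond the scatter. No available measurement bears on why the two methoxyphenyl groups read alike.

The compounds shown leave open whether this result holds with the methoxycarbonyl group of compound 1 in place of the ethoxycarbonyl group, since the exchange has been read only with the ethoxycarbonyl group. They also leave open whether a phenyl group without a methoxy group, or a phenyl group carrying a hydroxyl group or a chlorine atom, would give a number beyond the scatter at this place, and how a longer chain such as propoxycarbonyl would read on the ester side.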